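Sulfonylurea series: cyclohexyl for butyl on the chloro analogue

The compounds below may be only part of what the source reports. "The series", "measured", "known", "first", "only" and "open" are said of these compounds alone.

Compound 1 `CCCCNC(=O)NS(=O)(=O)c1ccc(-n2nc(-c3ccc(C)cc3)ccc2=O)cc1` is the reference point; in a functional assay on the whole organism (blood, strain Wistar albino) for inhibition, with Rattus norvegicus as the target, read by colorimetric assay, with stated times of 15 min and 90 min, at a dose of 20 mg/kg by the oral route (on this read-out lower numbers stand for less inhibition and higher numbers for more inhibition at the one dose given (going by the name of the read-out)), compound 1 gives 109%. Compound 2 `Cc1ccc(-c2ccc(=O)n(-c3ccc(S(=O)(=O)NC(=O)NC4CCCCC4)cc3)n2)cc1` carries the change cyclohexyl in place of butyl on an amide-type nitrogen and in this assay compound 2 gives 110%, so that a number 1 percentage points higher from compound 1 to compound 2 (within the scatter). Compound 3 `CCCCNC(=O)NS(=O)(=O)c1ccc(-n2nc(-c3ccc(Cl)cc3)ccc2=O)cc1` differs from compound 1 by chloro in place of methyl on an aromatic carbon, which is also how the two cores of this comparison differ; in this assay compound 3 gives 100%, so that a number 9 percentage points lower from compound 1 to compound 3 (within the scatter). Compound 3 thus sits as the lowest of the three numbers, but its gaps to compound 1 and compound 2 are both within the scatter, so no order is claimed among them.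

Compound 4 `O=C(NC1CCCCC1)NS(=O)(=O)c1ccc(-n2nc(-c3ccc(Cl)cc3)ccc2=O)cc1` has not yet been measured. It is built from compound 3 by cyclohexyl in place of butyl on an amide-type nitrogen, the same change as from compound 1 to compound 2, made on a core bearing chloro rather than methyl. On the methyl core that change moved the read-out only within the scatter, so for compound 4 a step of a number 1 percentage points higher from compound 3 to compound 4 (within the scatter) in this assay is expected, resting on compound 1 to compound 2 with a number 1 percentage points higher from compound 1 to compound 2 (within the scatter). Compound 4 is therefore estimated at 101% in this assay, with a range from 91% to 111%.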

Compound 4, a percentage reported as inhibition, in the whole organism at one dose (the size of the read-out at that dose, not a potency): 114%
For compound 4 the middle estimate is 13 percentage points below the measured one; the whole stated range lies below it.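

In this assay, the change of butyl to cyclohexyl on the chloro core gives a number 14 percentage points higher from compound 3 to compound 4 (beyond the scatter), yet this step cannot be told apart from the same change on the methyl core: the same change on two cores in this assay, a number 1 percentage points higher (within the scatter) from compound 1 to compound 2 and a number 14 percentage points higher (beyond the scatter) from compound 3 to compound 4, 13 percentage points apart, within the scatter of two such steps. The change of methyl to chloro, read with cyclohexyl in place, gives a number 4 percentage points higher from compound 2 to compound 4 (within the scatter), and it also agrees with its reading on the butyl pair: the same change on two cores in this assay, a number 9 percentage points lower (within the scatter) from compound 1 to compound 3 and a number 4 percentage points higher (within the scatter) from compound 2 to compound 4, 13 percentage points apart, within the scatter of two such steps. The change thus carries between these two cores with no difference beyond the scatter, but two pairs do not show that its size is the same on both cores, or that the chloro core responds to it differently.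

Open, going by these compounds, is how other groups on the amide-type nitrogen would read, such as a propyl chain, a cyclopentyl ring or a phenyl ring. Also open, on these data alone, is whether the agreement holds with other groups in place of chloro and methyl on the aromatic carbon, such as fluoro or methoxy.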